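From 2,3-dichlorophenyl to 3-bromo-4-hydroxyphenyl

A few compounds are considered here, and "the series" means these few. Any claim that something is new, unique, unknown or untested is made for them only; others in the source may bear on it.

Measured in a functional assay on HepG2 cells (Homo sapiens) for antiproliferative activity, read by MTT assay, with a stated time of 72 h (on this read-out higher numbers stand for weaker inhibition and lower numbers for stronger inhibition), were these compounds:
- compound 1 `O=C(N/N=C/c1ccccc1)Nc1ccc(Oc2ccnc3[nH]ccc23)c(F)c1` gives 640 nM
- compound 2 `O=C(N/N=C/c1cccc(Br)c1)Nc1ccc(Oc2ccnc3[nH]ccc23)c(F)c1` gives 660 nM
- compound 3 `O=C(N/N=C/c1cccc(Cl)c1Cl)Nc1ccc(Oc2ccnc3[nH]ccc23)c(F)c1` gives "not active" (no number reported)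

Compound 3 thus stands without a number on this scale. Compound 4 `O=C(N/N=C/c1ccc(O)c(Br)c1)Nc1ccc(Oc2ccnc3[nH]ccc23)c(F)c1` differs from it (3-bromo-4-hydroxyphenyl in place of 2,3-dichlorophenyl on a carbon with a double bond to nitrogen) with 3-bromo-4-hydroxyphenyl in place of 2,3-dichlorophenyl on a carbon with a double bond to nitrogen. Within the data shown here, the one measured step that bears on this is a 1.0-fold higher number from compound 1 to compound 2 (0.01 log units; within the scatter) for bromo in place of hydrogen on an aromatic carbon, and it lies within the scatter. Among the measured compounds shown here, without a number for compound 3, no step from it can be sized. A measurable value is nevertheless expected in this assay close to compound 1 (640 nM) and compound 2 (660 nM) with inhibition stronger than the report for compound 3 suggests. For compound 4 the expected value is 600 nM with an estimated range from 150 nM to 2500 nM as the half-maximal inhibitory concentration.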

Compound 4, half-maximal inhibitory concentration: 1360 nM
Beside the measured number, compound 4's estimate is 2.3-fold (0.36 log units) below it, and the stated range covers the measured number.
By their numbers in this assay, from the lowest: compounds 1 and 2 (each within the scatter of the next); then compound 4.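

In this assay, the hydroxy group produces a step that bromo alone did not: there is a 2.1-fold higher number from compound 2 to compound 4 (0.31 log units; beyond the scatter), and for the two groups together there is a 2.1-fold higher number from compound 1 to compound 4 (0.33 log units; beyond the scatter). Compound 4 still gives a number, unlike compound 3, but steps from compound 3 cannot be read. Nothing available gives a reason for the hydroxy step. As far as these compounds go, it remains open whether a methoxy group or an amine in place of the hydroxy would give a similar number. Also open, from the compounds shown here alone, is how hydroxy would read on the phenyl without bromo.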